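Swapping methoxy for methyl on a pyrrolidine-bearing aryl ring

The source may hold more compounds than are shown below. What is called first, only, known or untested is meant among the compounds shown, and "the series" means these compounds.

Compound 1 `COc1ccc([C@]2(CO)NC[C@@H](O)[C@@H]2O)cc1` gives 7.5%.
Compound 2 `OC[C@@]1(c2c(F)c(F)c(F)c(F)c2F)NC[C@@H](O)[C@@H]1O` gives 0%.
Compound 3 `COc1ccc([C@@]2(CO)NC[C@H](O)[C@H]2O)cc1OC` gives 0%.

These three compounds were tested in an assay on isolated protein for inhibition of alpha-galactosidase (Coffea arabica), tested at 1000 uM; a lower number here means less inhibition, a higher number more inhibition at the concentration tested (going by the name of the read-out). Compound 1 sits with its value at the upper end of the three numbers, yet its gap to compound 2 and its gap to compound 3 both lie within the usual scatter of such measurements, so the three compounds cannot be told apart on this evidence: all of them show little or no inhibition at the concentration tested.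

Compound 4 `Cc1ccc([C@]2(CO)NC[C@@H](O)[C@@H]2O)cc1` has not yet been measured. It differs from compound 1 in one place: methyl in place of methoxy on an aromatic carbon. Going by the values given here, no pair of measured compounds differing in a single position is available to show how large such a change tends to be in this assay, so the expectation rests only on the fact that every measured compound gives a near-zero value. The step of a number 2.5 percentage points lower from compound 1 to compound 4 (within the scatter) is therefore expected to be small, with no direction beyond the scatter. Compound 4 is estimated at 5%, in a range from 0% to 18%.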

Compound 4, a percentage reported as inhibition, at one concentration (the size of the read-out at that concentration, not a potency): 1.6%
Compound 4: the middle estimate sits 3.4 percentage points above what was measured; low and high end bracket the measured number.
By their numbers in this assay, from the lowest: compounds 2, 3, 4 and 1 (each within the scatter of the next).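

Going by these compounds alone, the first comparison of two compounds differing in one place in this assay replaces methoxy with methyl on the aromatic carbon, para to a group of 9 heavy atoms, and gives a number 5.9 percentage points lower from compound 1 to compound 4 (within the scatter). Removing the oxygen, and with it the single hydrogen-bond acceptor of the methoxy group, therefore leaves compound 1 and compound 4 impossible to tell apart in this read-out, and neither shows clear inhibition. No independent measurement bears on the reason for this result.

From the compounds shown here alone, it remains open whether any group at this position can lift inhibition clear of the scatter, as an amine, a carboxylic acid or a longer chain might or might not do. With all four values this low, this single step also cannot show how much the position matters in a compound with substantial inhibition.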